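A small ring in place of pyridyl on the triazole

The compounds below may be only part of what the source reports. "The series", "measured", "known", "first", "only" and "open" are said of these compounds alone.

Compound 1 `Cc1nc(CN(C)C)n(-c2ccc(Cl)cc2C(=O)c2ccccc2Cl)c1CO` was tested in a functional assay on the whole organism (strain CF-1) with Mus musculus as the target (on this read-out higher numbers stand for an effect only at larger amounts of compound and lower numbers for an effect already at smaller amounts), and gives 18 mg/kg. Compound 2 `CN(C)Cc1nnc(-c2ccncc2)n1-c1ccc(Cl)cc1C(=O)c1ccccc1Cl` shares the benzophenone part but carries a different five-membered core. In this assay compound 2 reached only the limit of the test, > 100 mg/kg, so no number is known for it. Within the data shown here, this is the situation described by the limit of > 100 mg/kg in this assay, at which 1 of the 2 values shown sits: one of the two values shown sits at that limit, and the two compounds differ in more than one place, so no single step can be drawn from compound 1 to compound 2.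

Compound 3 `CN(C)Cc1nnc(C2CC2)n1-c1ccc(Cl)cc1C(=O)c1ccccc1Cl` has not yet been measured. It differs from compound 2 by cyclopropyl in place of pyridin-4-yl on an aromatic carbon, on the five-membered aromatic ring with three nitrogen atoms, between two ring nitrogen atoms.

Among the measured compounds shown here, with no measured step to lean on, the expectation for compound 3 can only rest on the value of compound 1, 18 mg/kg, whose small methyl group on its own five-membered core gave a measurable dose. The step from compound 2 to compound 3 is expected to move downward, an at least 2.0-fold lower number from compound 2 to compound 3 (0.30 log units; that floor lies within the scatter), with considerable uncertainty. Compound 3 is therefore estimated at 50 mg/kg, with a range from 12 mg/kg to 200 mg/kg.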

Compound 3, dose for half-maximal effect: 7.1 mg/kg
Compound 3: the middle estimate sits 7.0-fold (0.85 log units) above what was measured; the whole stated range lies above it.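

This position on the five-membered aromatic ring with 3 nitrogen turns out to matter strongly: in this assay, cyclopropyl in place of pyridin-4-yl on the aromatic carbon between two ring nitrogen atoms gives an at least 14-fold lower number from compound 2 to compound 3 (1.14 log units; beyond the scatter). Going by these compounds, that figure is a minimum and the true size of the step stays unknown, since compound 2 sits at a limit of the test and not at a number: the limit of > 100 mg/kg in this assay, at which 1 of the 3 values shown sits. The swap also changes several things at once, namely the ring size, the aromatic character of the ring and the presence of a ring nitrogen, so this single step cannot say which of them counts.

On these data alone, a phenyl ring at this position would keep the six-membered aromatic ring without its nitrogen, and a cyclobutyl ring would test a slightly larger non-aromatic ring of carbon only, so how these two compare with compound 2 and compound 3 stays open. Also open, as far as these compounds go, is whether cyclopropyl would hold its effect if a pyrrolidinylmethyl group took the place of the (dimethylamino)methyl group.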